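Exchanging One Six-Membered Ring Group on a Shared Core

The compounds below may be only part of what the source reports. "The series", "measured", "known", "first", "only" and "open" are said of these compounds alone.

In a physicochemical assay for solubility, read by HPLC, in phosphate buffer, measured as kinetic solubility, with a stated time of 1 h, at pH 7.4, tested at 250 uM (on this read-out higher numbers stand for higher solubility and lower numbers for lower solubility), compound 2 (`CN1CCC(c2ccc3c(c2)oc(=O)n3C(=O)NCCCCc2ccccc2)CC1=O`) gives 20000 nM. Compound 1 (`CN1CCC(c2ccc3c(c2)oc(=O)n3C(=O)NCCCCc2ccc(F)cc2)CC1`) gives 22000 nM, a value within the scatter of compound 2. Compound 3 (`CC(C)CNC(=O)n1c(=O)oc2c(C3CCN(C)CC3)cccc21`) stands well apart at 230000 nM, a number beyond the scatter from both others.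

Compound 4 (`CN1CCN(c2ccc3c(c2)oc(=O)n3C(=O)NCCCCc2ccccc2)CC1`) has not yet been measured. It carries 4-methylpiperazin-1-yl in place of the 1-methyl-2-oxopiperidin-4-yl of compound 2, on an aromatic carbon: 4-methylpiperazin-1-yl in place of 1-methyl-2-oxopiperidin-4-yl on an aromatic carbon.

For the measured compounds named here, no two measured compounds differ in only one place, so this exchange has no direct precedent here. The best guide is indirect: compound 1 differs from compound 2 in more than one place, yet compound 1 at 22000 nM lies within the scatter of compound 2. A small rise, no larger than the scatter, is therefore expected, and the estimated step is a 1.5-fold higher number from compound 2 to compound 4 (0.18 log units; within the scatter). With so little evidence, the expected range stays wide. For compound 4 the estimated value is 30000 nM, within an expected range of 10000 nM to 100000 nM.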

Compound 4, solubility: < 1000 nM
Compound 4 was reported as a limit; the forecaster's own chance of this, stated with the estimate: 3%; at least 30-fold (1.47 log units) between middle value and limit.
By their numbers in this assay, from the lowest: compounds 2 and 1 (each within the scatter of the next); then compound 3. At a limit, below all of these: compound 4.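

In this assay compound 4 stands at < 1000 nM, which is a limit of the assay and not a number. Placing 4-methylpiperazin-1-yl in place of 1-methyl-2-oxopiperidin-4-yl on an aromatic carbon gives an at least 20-fold lower number from compound 2 to compound 4 (1.30 log units; beyond the scatter), so the read-out at this position is not indifferent to which six-membered ring group sits there, something the earlier compounds, none differing in only one place, could not show. The step is a bound and not a measured distance: the limit of < 1000 nM in this assay, at which 1 of the 4 values shown sits.

One pair cannot tell whether the result goes with the second ring nitrogen or with the missing carbonyl, and a morpholin-4-yl group at this place would help separate the two. Going by these compounds, whether the same exchange behaves alike with a longer chain on the shared core also stays open.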